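One Carbon More on an Isothiocyanate Chain

A few compounds are considered here, and "the series" means these few. Any claim that something is new, unique, unknown or untested is made for them only; others in the source may bear on it.

Compound 1, `CN(C)C(=O)c1cc2cnc(Nc3ccc(S(=O)(=O)NCCCCCN=C=S)cc3)nc2n1C1CCCC1`: 102%
Compound 2, `CN(C)C(=O)c1cc2cnc(Nc3ccc(S(=O)(=O)NCCCCCCN=C=S)cc3)nc2n1C1CCCC1`: 101%
Compound 3, `CN(C)C(=O)c1cc2cnc(Nc3ccc(C(=O)NCCCCCN=C=S)cc3F)nc2n1C1CCCC1`: 15.6%

Of the compounds shown here, three have been tested in a functional assay on A549 cells (Homo sapiens) for inhibition, read by CCK-8 assay, with a stated time of 72 h, tested at 10 uM; on this read-out higher numbers stand for a stronger effect at the one concentration tested and lower numbers for a weaker effect. Compound 1 and compound 2 share one core; compound 3 carries a different one, and the difference between the two cores is not broken down here. The step a group of 4 heavy atoms (2 carbon, 1 nitrogen, 1 sulfur; no ring) in place of a group of 3 heavy atoms (1 carbon, 1 nitrogen, 1 sulfur; no ring), on a saturated chain carbon, five bonds along the chain from a sulfonamide nitrogen brought a number 1 percentage points lower from compound 1 to compound 2 (within the scatter).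

Compound 4, `CN(C)C(=O)c1cc2cnc(Nc3ccc(C(=O)NCCCCCCN=C=S)cc3F)nc2n1C1CCCC1`, has not yet been measured in this assay. It stands to compound 3 as compound 2 stands to compound 1: the change is a group of 4 heavy atoms (2 carbon, 1 nitrogen, 1 sulfur; no ring) in place of a group of 3 heavy atoms (1 carbon, 1 nitrogen, 1 sulfur; no ring), on a saturated chain carbon, five bonds along the chain from an amide-type nitrogen. The two places differ in the nitrogen the chain hangs from, a sulfonamide nitrogen in compound 1 and an amide-type nitrogen in compound 3, so this is the same kind of change, not the same one.

Within the data shown here, since compound 3 is already the lowest of the three measured values, and the one earlier instance of this change left its pair within the scatter, compound 4 is expected to stay near compound 3. The estimated step is a number 1.4 percentage points higher from compound 3 to compound 4 (within the scatter). In this assay compound 4 is estimated at 17%, with a range from 5% to 32%.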

Compound 4, a percentage reported as inhibition, at one concentration (the size of the read-out at that concentration, not a potency): 22.9%
The estimate for compound 4 lay 5.9 percentage points below the measured number; the measured number falls inside the stated range.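

In this assay, the change on the isothiocyanate chain gave a number 7.3 percentage points higher from compound 3 to compound 4 (within the scatter), and set beside the earlier step the two agree: the same change on two cores in this assay, a number 1 percentage points lower (within the scatter) from compound 1 to compound 2 and a number 7.3 percentage points higher (within the scatter) from compound 3 to compound 4, 8.3 percentage points apart, within the scatter of two such steps

On these two pairs, then, the change carried from the core of compound 1 to the core of compound 3 without a step beyond the scatter on either. Among these compounds, this does not show that the change is without effect across the series: there are only two pairs, each read at a single concentration, which gives the size of the read-out and not a potency, and the two pairs differ in the core as well as in the nitrogen the chain hangs from, so these two cannot be told apart.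

Going by these compounds, whether a shorter or a longer chain would behave in the same way on either core remains open. So does what an amine or a carboxylic acid in place of the isothiocyanate would do to the read-out.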